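The source may hold more compounds than are shown below. What is called first, only, known or untested is meant among the compounds shown, and "the series" means these compounds.

In a functional assay on A549 cells (Homo sapiens) for cytotoxicity, read by MTT assay, with a stated time of 72 h (a higher number here means that more compound is needed for the effect, a lower number that less compound is needed), compound 1 `CCc1cccc2c(OC)c(-c3occ(C)c3C(=O)OC)ccc12` gives 1.5 ug/mL, and compound 2 `CCOc1c(-c2occ(C)c2C(=O)OC)ccc2c(CC)cccc12` gives 2.4 ug/mL; the two numbers lie within the scatter of each other, so neither stands apart. The step of a 1.6-fold higher number from compound 1 to compound 2 (0.20 log units; within the scatter) alters a chain on the ring oxygen, a different place and a different kind of exchange from the one now in question. Compound 3 `CCc1cccc2c(OC)c(-c3occ(C)c3CBr)ccc12` differs from compound 1 by bromomethyl in place of methoxycarbonyl on an aromatic carbon. For the measured compounds named here, no measured step bears on this exchange, so its size and direction have no precedent here. Compound 3 is therefore expected to give 1.5 ug/mL, with a range from 0.4 ug/mL to 6 ug/mL. The expected step is no change at the digits printed from compound 1 to compound 3 (within the scatter).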

Compound 3, concentration for half-maximal effect: > 10 ug/mL
Compound 3: a limit, no number; the forecaster's own chance of this, stated with the estimate: 5%; middle value at least 6.6-fold (0.82 log units) from the limit.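

Where the change on the ring oxygen stayed within the scatter, this exchange on the five-membered aromatic ring with 1 oxygen does not: in this assay, bromomethyl in place of methoxycarbonyl gives an at least 6.6-fold higher number from compound 1 to compound 3 (0.82 log units; beyond the scatter), so this position is sensitive to what it carries. Compound 3 stands at a limit of the assay, not at a number: the limit of > 10 ug/mL in this assay, at which 1 of the 3 values shown sits.

From the compounds shown here alone, the full size of the step stays open. So does the question of which part of the methoxycarbonyl matters, which a carboxylic acid, an amide or a hydroxymethyl at this position could help answer.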